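Compound 3 to compound 4: chloro to trifluoromethyl

This account rests on a few compounds, and the source may have more. Where it says the series, first, only, none or still open, it means among the compounds named here.

In an ADME assay on HEK293 cells (Homo sapiens) for cytotoxicity, read by resazurin assay, with a stated time of 48 h (a higher number here means that more compound is tolerated, a lower number that less compound is tolerated), compound 3 `O=S(=O)(Nc1ccc(-c2nc3ccccc3o2)cc1)c1cccc(Cl)c1` gives > 100000 nM, which is a limit and not a number. Compound 1 `O=S(=O)(Nc1ccc(-c2nc3ccccc3o2)cc1)c1cccc(F)c1` gives > 100000 nM, also a limit. Both sit at the limit of > 100000 nM in this assay, at which 2 of the 3 values shown sit. Compound 2 `O=S(=O)(Nc1ccc(-c2nc3ccccc3o2)cc1)c1ccc(Cl)c(C(F)(F)F)c1`, carrying chloro together with trifluoromethyl, gives a number, 69000 nM. Compound 4 `O=S(=O)(Nc1ccc(-c2nc3ccccc3o2)cc1)c1cccc(C(F)(F)F)c1` follows from compound 3 by trifluoromethyl in place of chloro on an aromatic carbon. For the measured compounds named here, the one measured step, a step that the two limits leave unreadable from compound 1 to compound 3, offers no size to carry over. Going by the values given here, the only guide is compound 2 at 69000 nM, so a small move towards less compound tolerated is expected, or none beyond the scatter. The expected step is an at least 1.1-fold lower number from compound 3 to compound 4 (0.04 log units; that floor lies within the scatter) in this assay. Compound 4 is estimated at 90000 nM, with a range of 50000 nM to 150000 nM.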

Compound 4, half-maximal cytotoxic concentration: > 100000 nM
Compound 4 ended at the assay's limit; the forecaster's own chance of this, stated with the estimate: 60%; middle value at least 1.1-fold (0.04 log units) from the limit.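

In this assay, trifluoromethyl on this aromatic carbon can now be read without the second chloro of compound 2, and hydrogen in place of that chloro gives an at least 1.4-fold higher number from compound 2 to compound 4 (0.16 log units; that floor lies within the scatter). The steps among compound 1, compound 3 and compound 4 cannot be read. Fluoro, chloro and trifluoromethyl at this place, in those three compounds, all share one limit: the limit of > 100000 nM in this assay, at which 3 of the 4 values shown sit.

Open, on these data alone, is whether an amine or a carboxylic acid at this place would give a number in this assay, and whether chloro added to compound 1 or compound 3 in the further place seen in compound 2 would do so.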